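This account rests on a few compounds, and the source may have more. Where it says the series, first, only, none or still open, it means among the compounds named here.

Measured in a functional assay on HCT-116 cells (Homo sapiens) for antiproliferative activity, read by CCK-8 assay, with a stated time of 72 h; on this read-out lower numbers stand for stronger inhibition and higher numbers for weaker inhibition:
compound 1 `Nc1ccccc1NC(=O)c1ccc(Cn2cnc3c(NCc4ccccc4)nc(Cl)nc32)cc1`: 1060 nM
compound 2 `CC(C)n1cnc2c(NCc3ccc(C(=O)Nc4ccccc4N)cc3)nc(Cl)nc21`: 800 nM

Compound 1, at 1060 nM, lies within the scatter of compound 2, so neither stands apart. Compound 3 `Nc1ccccc1NC(=O)c1ccc(Cn2cnc3c(Nc4cccc(Cl)c4)nc(Cl)nc32)cc1` departs from compound 1 in one place: 3-chlorophenyl in place of benzyl on a nitrogen on an aromatic ring, with 3-chlorophenyl in place of benzyl on a nitrogen on an aromatic ring. Going by the values given here, no measured pair isolates this change, so no step beyond the scatter is expected in this assay, and no direction is favoured. The estimated result is a 1.3-fold lower number from compound 1 to compound 3 (0.12 log units; within the scatter). For compound 3 the expected value is 800 nM, with an estimated range of 250 nM to 2500 nM.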

Compound 3, half-maximal inhibitory concentration: 2340 nM
The estimate for compound 3 lay 2.9-fold (0.47 log units) below the measured number; measured number inside the range.
By their numbers in this assay, from the lowest: compounds 2 and 1 (each within the scatter of the next); then compound 3.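

In this assay, going by these compounds alone, 3-chlorophenyl in place of benzyl on the nitrogen gives a 2.2-fold higher number from compound 1 to compound 3 (0.34 log units; beyond the scatter) as the first readable step at this position. This single pair shows that the position does not accept every seven-atom aromatic group equally, as benzylamino and (3-chlorophenyl)amino differ beyond the scatter. No available evidence bears on the origin of this step.

Still open, on these data alone, is whether the step follows the chlorine or the change from benzyl to a ring directly on the nitrogen. Unsubstituted phenyl and 3-chlorobenzyl at this position would separate the two.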